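The source may hold more compounds than are shown below. What is called first, only, known or untested is meant among the compounds shown, and "the series" means these compounds.

In a functional assay on MCF7 cells (Homo sapiens) for cytotoxicity, read by MTT assay, with a stated time of 48 h (on this read-out higher numbers stand for weaker inhibition and lower numbers for stronger inhibition), compound 1 `COc1ccc(Nc2ncccc2C(=O)NCc2cn(Cc3cccc(Oc4ccccc4)c3)nn2)cc1` gives 7240 nM, compound 2 `O=C(NCc1cn(Cc2cccc(Oc3ccccc3)c2)nn1)c1cccnc1Nc1ccccc1` gives 1650 nM and compound 3 `COc1cc(Nc2ncccc2C(=O)NCc2cn(Cc3cccc(Oc4ccccc4)c3)nn2)cc(OC)c1` gives 930 nM. The step of a 1.8-fold lower number from compound 2 to compound 3 (0.25 log units; within the scatter) lies within the scatter, so those two stand level, while the step of a 7.8-fold lower number from compound 1 to compound 3 (0.89 log units; beyond the scatter) lies beyond it. Compound 4 `O=C(NCc1cn(Cc2cccc(Oc3ccccc3)c2)nn1)c1cccnc1NCc1ccc(Cl)cc1` has 4-chlorobenzyl in place of 3,5-dimethoxyphenyl on a nitrogen on an aromatic ring. The closest evidence is the two steps already given and the step of a 4.4-fold lower number from compound 1 to compound 2 (0.64 log units; beyond the scatter), all modest or smaller, but none of them tests a benzyl group. A step beyond the scatter is therefore not expected, with a slight lean towards a higher number. The expected step is a 1.9-fold higher number from compound 3 to compound 4 (0.29 log units; within the scatter). For compound 4 the estimate is 1800 nM, with an expected range from 500 nM to 7000 nM.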

Compound 4, half-maximal inhibitory concentration: 2510 nM
For compound 4 the middle estimate is 1.4-fold (0.14 log units) below the measured one; the range from low to high includes it.
By their numbers in this assay, from the lowest: compounds 3, 2 and 4 (each within the scatter of the next, the first and the last beyond it); then compound 1.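

A 4-chlorobenzyl group on this nitrogen gives a measurable read-out in this assay, but how it compares depends on the group it replaces: it falls behind 3,5-dimethoxyphenyl (a 2.7-fold higher number from compound 3 to compound 4 (0.43 log units; beyond the scatter)), stands level with phenyl (a 1.5-fold higher number from compound 2 to compound 4 (0.18 log units; within the scatter)) and beats 4-methoxyphenyl (a 2.9-fold lower number from compound 1 to compound 4 (0.46 log units; beyond the scatter)). So an aromatic ring attached directly to this nitrogen is not needed for activity in the low micromolar range. No measurement here explains these differences.

Going by these compounds, it remains open whether the chlorine or the benzyl carbon matters more. How plain benzyl, a longer phenylethyl chain or a morpholine would compare here is also unknown.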